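From anilino to piperidin-1-yl on a shared core

The source may report more compounds than this note shows. Statements on the series, on what has been measured and on what is new or still open speak of the compounds shown alone.

In a functional assay on MCF7 cells (Homo sapiens) for inhibition, read by sulforhodamine B assay (a higher number here means a weaker inhibitor, a lower number a stronger inhibitor), compound 1 `O=C1C=C(Nc2ccc(Br)cc2)C(=O)c2c1nc1n2[C@H]2OC[C@@H](O)[C@H]2OC1` gives 2580 nM as its half-maximal inhibitory concentration. Compound 2 `O=C1C=C(Nc2ccccc2)C(=O)c2c1nc1n2[C@H]2OC[C@@H](O)[C@H]2OC1` gives > 4000 nM in the same read-out, and that is a limit, not a number. Compound 2 therefore sits at the limit of > 4000 nM in this assay, at which 1 of the 2 values shown sits, and has no exact place of its own. Compound 3 `O=C1C=C(N2CCCCC2)C(=O)c2c1nc1n2[C@H]2OC[C@@H](O)[C@H]2OC1` carries piperidin-1-yl in place of anilino on a double-bonded ring carbon, a change counted as piperidin-1-yl in place of anilino on a double-bonded ring carbon on the shared core. Among the compounds with values here, the one measured step, hydrogen in place of bromo on an aromatic carbon, is an at least 1.5-fold higher number from compound 1 to compound 2 (0.19 log units; that floor lies within the scatter) and it leaves the anilino in place, so it sets no size for this change. No step beyond the scatter is therefore expected in this assay here. The expected change is a number no higher from compound 2 to compound 3 (the limit leaves the size open) on this estimate. For compound 3 the estimated value is 4000 nM with an expected range of 1500 nM to 10000 nM in this read-out.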

Compound 3, half-maximal inhibitory concentration: > 8000 nM
Compound 3: no number, only a limit; the forecaster's own chance of this, stated with the estimate: 50%; at least 2.0-fold (0.30 log units) between middle value and limit.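

In this assay compound 3 gives no exact number, only a limit: > 8000 nM. Compound 2 also has only a limit, so the direct step from anilino to piperidin-1-yl on the double-bonded ring carbon cannot be read: the limit of > 4000 nM in this assay, at which 1 of the 3 values shown sits.

Within the data shown here, what can be read is that piperidin-1-yl in place of (4-bromophenyl)amino gives an at least 3.1-fold higher number from compound 1 to compound 3 (0.49 log units; beyond the scatter), the first step in this set that lies beyond the scatter.

The compounds shown leave open how an open-chain amine such as dimethylamino, or a morpholin-4-yl ring, would read on this carbon. They also leave open whether a chloro or methoxy group on the anilino ring would give an exact value like that of compound 1 or only a limit like those of compound 2 and compound 3.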